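This account rests on a few compounds, and the source may have more. Where it says the series, first, only, none or still open, it means among the compounds named here.

Three close relatives built on one shared core have so far been tested in a functional assay on thoracic aorta (Rattus norvegicus) for inhibition; on this read-out higher numbers stand for an effect only at larger amounts of compound and lower numbers for an effect already at smaller amounts. Compound 1 `CC1(C)CC(NC(=S)Nc2cccc(C#N)c2)c2cc(NS(C)(=O)=O)ccc2O1` gives 9800 nM. Compound 2 `CC1(C)CC(NC(=S)Nc2ccc(C#N)cc2)c2cc(NS(C)(=O)=O)ccc2O1` gives 11600 nM, and compound 3 `CCS(=O)(=O)Nc1ccc2c(c1)C(NC(=S)Nc1cccc(C#N)c1)CC(C)(C)O2` gives 12100 nM. The number for compound 3 lies within the usual scatter of both others, so the three cannot be told apart on these measurements.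

Compound 4 `CCS(=O)(=O)Nc1ccc2c(c1)C(NC(=S)Nc1ccc(C#N)cc1)CC(C)(C)O2` has not yet been measured. It differs from compound 3 in a single place: 4-cyanophenyl in place of 3-cyanophenyl on an amide-type nitrogen. The same exchange has been made once before, between compound 1 and compound 2, where it produced a 1.2-fold higher number from compound 1 to compound 2 (0.07 log units; within the scatter). Within the data shown here, the only other measured step, a 1.2-fold higher number from compound 1 to compound 3 (0.09 log units; within the scatter), touches a different part of the molecule and likewise stayed within the scatter, so nothing among the measured compounds points to a shift from this kind of change.

On that basis the expected step is a 1.1-fold higher number from compound 3 to compound 4 (0.05 log units; within the scatter), a change that stays within the scatter. Compound 4 is therefore estimated to give 13500 nM in this assay, with a range from 7000 nM to 27000 nM.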

Compound 4, half-maximal effective concentration: 12000 nM
Compound 4: middle estimate off by 1.1-fold (0.05 log units), on the high side, within the range that was stated.
By their numbers in this assay, from the lowest: compounds 1, 2, 4 and 3 (each within the scatter of the next).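

In this assay the exchange of 3-cyanophenyl for 4-cyanophenyl on an amide-type nitrogen now has a second reading on another core, a 1.0-fold lower number from compound 3 to compound 4 (0.00 log units; within the scatter) and this agrees with the first reading: the same change on two cores in this assay, a 1.2-fold higher number (0.07 log units; within the scatter) from compound 1 to compound 2 and a 1.0-fold lower number (0.00 log units; within the scatter) from compound 3 to compound 4, 1.2-fold (0.08 log units) apart, within the scatter of two such steps. Methyl in place of hydrogen on a saturated chain carbon bound to a sulfonyl sulfur also has a second reading, now with 4-cyanophenyl present, a 1.0-fold higher number from compound 2 to compound 4 (0.01 log units; within the scatter) and again the two readings agree: the same change on two cores in this assay, a 1.2-fold higher number (0.09 log units; within the scatter) from compound 1 to compound 3 and a 1.0-fold higher number (0.01 log units; within the scatter) from compound 2 to compound 4, 1.2-fold (0.08 log units) apart, within the scatter of two such steps. Each change therefore stays within the scatter whichever of the two forms the other place carries, so neither place separates these compounds on this read-out.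

The compounds shown leave open what happens when the phenyl ring on the amide-type nitrogen carries a chlorine or a methoxy group in place of the nitrile, or when that ring gives way to a pyridine. They also leave open whether a longer chain on the sulfonyl sulfur, such as butyl, would still make so small a step.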